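Pyridinyl for methoxyphenyl on the alkenyl arm

The source may hold more compounds than are shown below. What is called first, only, known or untested is meant among the compounds shown, and "the series" means these compounds.

Compound 1 `COc1ccc(/C=C/C[C@H]2C[C@@H]([C@@H](O)c3ccccc3)CO[C@@H]2c2ccccc2)cc1` gives 8300 nM in a functional assay on HeLa cells (Homo sapiens) for cytotoxicity, read by WST assay, with a stated time of 48 h; on this read-out higher numbers stand for weaker inhibition and lower numbers for stronger inhibition. Among the measured compounds shown here, its number is the lowest of the three measured so far. Compound 3 `COc1cccc(/C=C/C[C@H]2C[C@@H]([C@@H](O)c3ccc(OC)c(OC)c3)CO[C@@H]2c2ccc(OC)c(OC)c2)c1` gives 14000 nM, a value that lies within the scatter of compound 1, so the two cannot be ordered. Compound 2 `COc1cccc([C@H](O)[C@H]2CO[C@@H](c3ccc(OC)c(OC)c3)[C@H](C/C=C/c3ccc(OC)c(OC)c3)C2)c1` gives 18600 nM, a higher number than compound 1 that lies beyond the scatter. Compound 4 `O[C@@H](c1ccccc1)[C@H]1CO[C@H](c2ccccc2)[C@@H](C/C=C/c2cccnc2)C1` has not been measured in this assay. It differs from compound 1 in one place: pyridin-3-yl in place of 4-methoxyphenyl on a double-bonded chain carbon bound to a double-bonded chain carbon. For the measured compounds named here, no measured pair shows this change, so no step can be read from the data. Compound 4 is expected to give 10000 nM, with a range from 4000 nM to 25000 nM, a step of a 1.2-fold higher number from compound 1 to compound 4 (0.08 log units; within the scatter) that is expected to stay within the scatter.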

Compound 4, half-maximal inhibitory concentration: > 100000 nM
Compound 4: only a limit was reported (the forecaster's own chance of this, stated with the estimate: 10%); middle value at least 10-fold (1.00 log units) away from the limit.
By their numbers in this assay, from the lowest: compounds 1, 3 and 2 (each within the scatter of the next, the first and the last beyond it). At a limit, above all of these: compound 4.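

The earlier compounds shown here differ from one another in more than one place, so they said nothing about this position alone. Here a single change, pyridin-3-yl in place of 4-methoxyphenyl on a double-bonded chain carbon bound to a double-bonded chain carbon, gives an at least 12-fold higher number from compound 1 to compound 4 (1.08 log units; beyond the scatter) in this assay, which shows that this position does not tolerate every aromatic ring. The value of compound 4 is a limit: the limit of > 100000 nM in this assay, at which 1 of the 4 values shown sits.

The compounds shown leave open whether the large step goes with the ring nitrogen or with the lost methoxy group. An unsubstituted phenyl or a pyridin-4-yl at this place would separate the two.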